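The source may report more compounds than this note shows. Statements on the series, on what has been measured and on what is new or still open speak of the compounds shown alone.

Measured so far:
compound 1 `ClCc1ccccc1Cn1cnc2c(Cl)nc(Cl)nc21` — 1820 nM
compound 2 `ClCc1cccc(Cn2cnc3c(Cl)ncnc32)c1` — 77600 nM

Both numbers come from a functional assay on MCF7 cells (Homo sapiens) for cytotoxicity, read by sulforhodamine B assay, with a stated time of 48 h; a lower number here means a stronger inhibitor of growth, a higher number a weaker inhibitor of growth. Compound 2 stands at the highest of the two numbers; compound 1 gives a far lower number, a gap beyond the scatter. Compound 3 `ClCc1cccc(Cn2cnc3c(Cl)nc(Cl)nc32)c1` differs from compound 2 by chloro in place of hydrogen on an aromatic carbon. Going by the values given here, no measured pair shows this change alone, so its size is not known here. The step is nonetheless expected to lower the number in this assay beyond the scatter, because compound 1, which also carries this chloro on the core, gives 1820 nM while compound 2 gives 77600 nM. Compound 3 is estimated at 5000 nM, range 1500 nM to 25000 nM. The expected step is a 16-fold lower number from compound 2 to compound 3 (1.19 log units; beyond the scatter).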

Compound 3, concentration for total growth inhibition: 6450 nM
For compound 3 the middle estimate is 1.3-fold (0.11 log units) below the measured one; measured number inside the range.
By their numbers in this assay, from the lowest: compound 1; then compound 3; then compound 2.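

In this assay, chloro in place of hydrogen on the aromatic carbon between two ring nitrogen atoms now has a size of its own, a large change: a 12-fold lower number from compound 2 to compound 3 (1.08 log units; beyond the scatter). Until now it could be read only from compound 1 and compound 2, which also differ in a second place. No measurement shown here bears on the reason for this step.

As far as these compounds go, whether an amine or a methoxy group on the same carbon would give a similar step remains open. So does the size of this step with the other substituent pattern of compound 1.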